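The compounds below may be only part of what the source reports. "The series", "measured", "known", "first", "only" and "open" are said of these compounds alone.

In a functional assay on SMMC-7721 cells (Homo sapiens) for inhibition, read by MTT assay, with a stated time of 48 h (on this read-out higher numbers stand for weaker inhibition and lower numbers for stronger inhibition), two compounds sharing one core have been measured so far. Compound 1 `CC(C)c1cccc(NC(=O)Nc2cccc(-c3cccc4[nH]nc(N)c34)c2)c1` gives 280 nM and compound 2 `Nc1n[nH]c2cccc(-c3cccc(NC(=O)Nc4nccs4)c3)c12` gives 550 nM. These two numbers lie within the usual scatter of repeated measurements, so compound 2 stands level with compound 1 on the present evidence.

Compound 3 `Nc1n[nH]c2cccc(-c3cccc(NC(=O)Nc4ccccc4F)c3)c12` keeps the shared core and differs from compound 2 in one group: 2-fluorophenyl in place of 1,3-thiazol-2-yl on an amide-type nitrogen. Put simply, 2-fluorophenyl takes the place of 1,3-thiazol-2-yl on an amide-type nitrogen.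

Among the compounds with values here, only one measured step bears on this place. That step, a 2.0-fold higher number from compound 1 to compound 2 (0.29 log units; within the scatter), exchanged 3-isopropylphenyl for 1,3-thiazol-2-yl on the same nitrogen and stayed within the scatter. Within the data shown here, it is a single step, and no fluorinated compound has been measured, so the evidence is thin. Even so, no shift beyond the scatter is expected in this assay, in either direction.

The estimated change is a 1.4-fold lower number from compound 2 to compound 3 (0.14 log units; within the scatter). For compound 3 the expected value is 400 nM, with an estimated range from 150 nM to 1100 nM.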

Compound 3, half-maximal inhibitory concentration: 2360 nM
The estimate for compound 3 lay 5.9-fold (0.77 log units) below the measured number, and the stated range ends below it.
By their numbers in this assay, from the lowest: compounds 1 and 2 (each within the scatter of the next); then compound 3.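

In this assay, the result shows that this place on the amide-type nitrogen is not indifferent to the group it carries: the earlier exchange stayed within the scatter, whereas 2-fluorophenyl in place of 1,3-thiazol-2-yl gives a 4.3-fold higher number from compound 2 to compound 3 (0.63 log units; beyond the scatter) and moves clearly beyond it. The comparison with 3-isopropylphenyl points the same way, with an 8.4-fold higher number from compound 1 to compound 3 (0.93 log units; beyond the scatter), so a six-membered aromatic ring of carbon alone does not decide the outcome: compound 1 and compound 3 both carry such a ring, yet their numbers lie well apart. Nothing measured alongside these numbers explains why the change from compound 2 to compound 3 has this size.

The compounds shown leave open whether the higher number goes with the fluorine itself or with the ring that carries it, a question that a plain phenyl group in this place would help to separate. On these data alone, it also remains open how an amine or a carboxylic acid on that ring would shift the number, and in which direction.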